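Moving the propargyloxy chain across the pendant phenyl

A few compounds are considered here, and "the series" means these few. Any claim that something is new, unique, unknown or untested is made for them only; others in the source may bear on it.

Two compounds of this series have been examined. Compound 1 `C#CCOc1ccccc1-c1cc(-c2ccccc2OCC#C)nc(N)n1` was reported in an assay on BTI-TN-5B1-4 cells for inhibition of Amine oxidase [flavin-containing] A (Homo sapiens), read by fluorescence and Amplex Red, using microsomes, with a stated time of 30 min (on this read-out higher numbers stand for weaker inhibition and lower numbers for stronger inhibition), as "not active" (no number reported), with no number given. Among the compounds with values here, compound 2 `C#CCOc1ccc(-c2cc(-c3ccccc3OCC#C)nc(-c3ccccc3)n2)cc1` is the only member of the series with a number: in this assay compound 2 gives 22000 nM, a weak inhibition, and it is therefore the only point of reference for the series.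

Compound 3 `C#CCOc1ccccc1-c1cc(-c2ccccc2OCC#C)nc(-c2ccccc2)n1` keeps every atom of compound 2 but joins them differently: a group of 10 heavy atoms (9 carbon, 1 oxygen; one six-membered aromatic ring of carbon only) in place of a group of 10 heavy atoms (9 carbon, 1 oxygen; one six-membered aromatic ring of carbon only), on an aromatic carbon. The 4-(propargyloxy)phenyl group leaves and a group of the same composition, bearing its propargyloxy chain at a different ring carbon, enters on the shared core.

Within the data shown here, no pair of measured compounds isolates this change, so no measured step is available to size it. Compound 1, which also carries both propargyloxy chains in the arrangement of compound 3, showed no activity, which points to a step toward weaker inhibition. Compound 3 is expected to be weaker than compound 2, the estimated step being a 2.0-fold higher number from compound 2 to compound 3 (0.31 log units; beyond the scatter). The estimate for compound 3 in this assay is 45000 nM, with a range from 15000 nM to 150000 nM, and a real chance that only a limit is reported.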

Compound 3, half-maximal inhibitory concentration: "not active" (no number reported)
The entry for compound 3 holds no number; no gap can be computed for the estimate.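

In this assay, within the data shown here, compound 3 carries no number, so no step from compound 2 to compound 3 can be read. The compounds shown leave open how large a change in inhibition goes with moving the propargyloxy chain to a different carbon of the pendant phenyl ring. Nothing shown offers an explanation for this result.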